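Free amine in place of diacetylamino at the thiazole-type core

A few compounds are considered here, and "the series" means these few. Any claim that something is new, unique, unknown or untested is made for them only; others in the source may bear on it.

Measured so far in an assay for inhibition of Dihydrofolate reductase (Bos taurus), with stated times of 1 min and 10 min; a higher number here means a weaker inhibitor, a lower number a stronger inhibitor:
compound 1 `CC(=O)N(C(C)=O)c1nc(-c2nnc(S)n2-c2ccc(Cl)cc2)cs1`: 10000 nM
compound 2 `CC(=O)N(C(C)=O)c1nc(-c2nnc(S)n2-c2ccccc2)cs1`: 35000 nM
compound 3 `COc1ccc(-n2c(S)nnc2-c2csc(N(C(C)=O)C(C)=O)n2)cc1`: 5000 nM

Compound 1 sits in the middle of the three numbers. Its nearest neighbour is compound 3, with a 2.0-fold lower number from compound 1 to compound 3 (0.30 log units; within the scatter), a gap that stays within the scatter. The furthest is compound 2, with a 3.5-fold higher number from compound 1 to compound 2 (0.54 log units; beyond the scatter). Between the other two, a 7.0-fold lower number from compound 2 to compound 3 (0.85 log units; beyond the scatter).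

The step to the unmeasured compound 4 `Nc1nc(-c2nnc(S)n2-c2ccc(Cl)cc2)cs1` is a different kind of change: amino in place of diacetylamino on an aromatic carbon. All three measured steps alter the substituent on the phenyl ring and leave the diacetylamino group untouched, so none of them bears directly on this exchange. The measured series gives no guidance on how this assay responds to removing the two acetyl groups at this position, and the expectation therefore rests on compound 1 alone with a wide margin.

On that basis compound 4 is estimated at 6000 nM in this assay, with a range from 1000 nM to 35000 nM. This estimate means a step of a 1.7-fold lower number from compound 1 to compound 4 (0.22 log units; within the scatter), which is not expected to exceed the scatter with any confidence.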

Compound 4, half-maximal inhibitory concentration: 18000 nM
The estimate for compound 4 lay 3.0-fold (0.48 log units) below the measured number; the measured number falls inside the stated range.
By their numbers in this assay, from the lowest: compounds 3, 1, 4 and 2 (each within the scatter of the next, the first and the last beyond it).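

In this assay, exchanging diacetylamino for amino on the aromatic carbon of the five-membered ring gives (a 1.8-fold higher number from compound 1 to compound 4 (0.26 log units; within the scatter)), so this position takes a large change in the group with no change in the number beyond the scatter. Seven heavy atoms leave and one enters, the two carbonyl-bearing acetyl groups are gone and a hydrogen-bond donor appears, yet this step is smaller than the phenyl-substituent step (a 7.0-fold lower number from compound 2 to compound 3 (0.85 log units; beyond the scatter)), which is the only kind of change that has so far moved the number beyond the scatter in this series, and which also separates compound 2 from compound 3. No supporting measurement is available to explain why the number holds across this exchange.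

From the compounds shown here alone, it remains open whether a single acetyl on the nitrogen, as in an acetylamino group, or a methylamino or dimethylamino group would also stay within the scatter of compound 1. Going by these compounds, it also remains open whether the same exchange to amino reads alike with the unsubstituted phenyl of compound 2 or the methoxy-bearing phenyl of compound 3.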